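This account rests on a few compounds, and the source may have more. Where it says the series, first, only, none or still open, it means among the compounds named here.

Measured compounds in a functional assay on UACC-257 cells (Homo sapiens) for antiproliferative activity, with a stated time of 48 h; on this read-out lower numbers stand for stronger inhibition of growth and higher numbers for weaker inhibition of growth:
- compound 1 `Cc1cc(O)c(C2=NN(c3ccc(S(N)(=O)=O)cc3)C(c3ccccc3O)C2)cc1Cl`: 22100 nM
- compound 2 `Cc1cc(O)c(C2=NN(c3ccc(S(N)(=O)=O)cc3)C(c3ccccc3Cl)C2)cc1Cl`: 79600 nM
- compound 3 `Cc1cc(O)c(C2=NN(c3ccc(S(N)(=O)=O)cc3)C(/C=C/c3ccccc3)C2)cc1Cl`: 45700 nM

Compound 2 gives the highest number of the three. Its nearest neighbour is compound 3, with a 1.7-fold lower number from compound 2 to compound 3 (0.24 log units; within the scatter); its furthest is compound 1, with a 3.6-fold higher number from compound 1 to compound 2 (0.56 log units; beyond the scatter) read the other way.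

Compound 4 `COc1ccc(C2CC(c3cc(Cl)c(C)cc3O)=NN2c2ccc(S(N)(=O)=O)cc2)cc1OC` is not yet measured. It differs from compound 2 by 3,4-dimethoxyphenyl in place of 2-chlorophenyl on a saturated ring carbon.

Going by the values given here, two measured steps bear on this. Replacing the group on that saturated ring carbon, as in a 1.7-fold lower number from compound 2 to compound 3 (0.24 log units; within the scatter), stayed within the scatter. Altering a single ring substituent, as in a 3.6-fold higher number from compound 1 to compound 2 (0.56 log units; beyond the scatter), gave a modest step. Among the compounds with values here, no measured pair carries a 3,4-dimethoxyphenyl, so the direction for compound 4 rests only on compound 2 sitting highest: a move is more likely downward than further up, and a modest one at most. The expected step is a 1.8-fold lower number from compound 2 to compound 4 (0.25 log units; within the scatter). Compound 4 is accordingly estimated at 45000 nM in this assay, with a range from 15000 nM to 100000 nM.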

Compound 4, concentration for total growth inhibition: 19700 nM
Estimate against measurement, compound 4: 2.3-fold (0.36 log units) above; low and high end bracket the measured number.
By their numbers in this assay, from the lowest: compounds 4 and 1 (each within the scatter of the next); then compounds 3 and 2 (each within the scatter of the next).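

In this assay, the saturated ring carbon accepts a group other than 2-hydroxyphenyl at the low end of the series: 3,4-dimethoxyphenyl in place of 2-chlorophenyl gives a modest gain (a 4.0-fold lower number from compound 2 to compound 4 (0.61 log units; beyond the scatter)), and in place of 2-phenylethenyl a smaller one (a 2.3-fold lower number from compound 3 to compound 4 (0.37 log units; beyond the scatter)). Set against 2-hydroxyphenyl, the change stays within the scatter (a 1.1-fold lower number from compound 1 to compound 4 (0.05 log units; within the scatter)), so a hydroxy group on this phenyl ring is not required for the lower numbers in these four compounds.

Nothing available explains why these groups differ. As far as these compounds go, it remains open whether the gain needs both methoxy groups, and how a single methoxy, an amine or a carboxylic acid on that phenyl ring would read in this assay.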